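Chloro for Methoxy: From Compound 3 Toward Compound 4

The compounds below may be only part of what the source reports. "The series", "measured", "known", "first", "only" and "open" are said of these compounds alone.

Compound 1, `COc1ccccc1-c1cc(N2CCC(CNS(N)(=O)=O)CC2)ncn1`, in a functional assay on M21 cells (Homo sapiens) for antiproliferative activity, read by sulforhodamine B assay, with a stated time of 48 h (on this read-out lower numbers stand for stronger inhibition of growth and higher numbers for weaker inhibition of growth), gives > 100000 nM, a limit of the assay. Compound 2, `NS(=O)(=O)NCC1CCN(c2cc(-c3ccccc3Cl)ncn2)CC1`, gives > 100000 nM, likewise a limit. Compound 3, `COc1ccc(-c2cc(N3CCC(CCNS(N)(=O)=O)CC3)ncn2)cc1`, gives 69800 nM.

Going by the values given here, the one measured instance of the change, a step that the two limits leave unreadable from compound 1 to compound 2, is chloro in place of methoxy on an aromatic carbon; its size cannot be read because both values sit at the limit of > 100000 nM in this assay, at which 2 of the 3 values shown sit. Compound 4, `NS(=O)(=O)NCCC1CCN(c2cc(-c3ccc(Cl)cc3)ncn2)CC1`, differs from compound 3 by chloro in place of methoxy on an aromatic carbon. It is the same kind of change, not the same: in compound 2 the chloro stands ortho to a large group, in compound 4 para to a large group. The difference between the two cores is not broken down here.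

Compound 4 is expected to give 80000 nM, between 30000 nM and 200000 nM. The expected step of a 1.1-fold higher number from compound 3 to compound 4 (0.06 log units; within the scatter) rests on compound 3 at 69800 nM, with no readable measured step to shift it.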

Compound 4, concentration for 50% growth inhibition: 45200 nM
Compound 4: the middle estimate sits 1.8-fold (0.25 log units) above what was measured, within the range that was stated.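

In this assay, chloro in place of methoxy, para to a large group, gives a 1.5-fold lower number from compound 3 to compound 4 (0.19 log units; within the scatter). Going by these compounds alone, this is the only readable instance of the change, and on the core of compound 3 it shows no shift beyond the scatter. The step on the core of compound 1 cannot be read, so the result cannot be carried from one core to the other, and a chloro ortho to a large group remains untested by any readable step: the limit of > 100000 nM in this assay, at which 2 of the 4 values shown sit.

The compounds shown leave open whether an amine or a carboxylic acid on that same aromatic carbon would give a step beyond the scatter. They also leave open whether a nitrile there would do so on either core.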